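Aryl for alkyl on the oxazole: a predicted cytotoxicity step

The source may hold more compounds than are shown below. What is called first, only, known or untested is meant among the compounds shown, and "the series" means these compounds.

Measured so far in a functional assay on PC-3 cells (Homo sapiens) for cytotoxicity, read by sulforhodamine B assay, tested at 10 uM; a higher number here means more inhibition at the concentration tested (going by the name of the read-out), a lower number less inhibition:
compound 1, `CC(=O)OC[C@H]1O[C@@H](n2cc(-c3cn(Cc4ccccc4)nn3)c(=O)[nH]c2=O)C[C@@H]1OC(C)=O`, gives 92.1%
compound 2, `CCCCc1ccc(-c2cc(-c3cn([C@H]4C[C@H](OC(C)=O)[C@@H](COC(C)=O)O4)c(=O)[nH]c3=O)on2)cc1`, gives 30.4%
compound 3, `CCCCCc1cc(-c2cn([C@H]3C[C@H](OC(C)=O)[C@@H](COC(C)=O)O3)c(=O)[nH]c2=O)on1`, gives 93.9%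

Compound 3 stands highest of the three numbers, with compound 1 within the scatter of it and compound 2 far below. Compound 4, `CC(=O)OC[C@H]1O[C@@H](n2cc(-c3cc(-c4ccccc4)no3)c(=O)[nH]c2=O)C[C@@H]1OC(C)=O`, differs from compound 3 by phenyl in place of pentyl on an aromatic carbon. Among the compounds with values here, only one measured step bears on this: a number 63.5 percentage points higher from compound 2 to compound 3 (beyond the scatter), where an aryl group gave way to an alkyl chain. The present change goes the other way, alkyl to aryl, though the entering phenyl is smaller than the 4-butylphenyl that left. A downward step is therefore expected, likely smaller than that one, so a number 38.9 percentage points lower from compound 3 to compound 4 (beyond the scatter) is estimated. Compound 4 is expected to give about 55%, in the range 20% to 90%.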

Compound 4, a percentage reported as inhibition, at one concentration (the size of the read-out at that concentration, not a potency): 85.5%
The estimate for compound 4 lay 30.5 percentage points below the measured number; measured number inside the range.
By their numbers in this assay, from the lowest: compound 2; then compounds 4, 1 and 3 (each within the scatter of the next).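

In this assay, phenyl in place of pentyl on this aromatic carbon gives a number 8.4 percentage points lower from compound 3 to compound 4 (within the scatter), so among these compounds an aryl group here does not by itself bring the number down. The drop seen for compound 2 goes with its butyl group: hydrogen in place of butyl gives a number 55.1 percentage points higher from compound 2 to compound 4 (beyond the scatter). No evidence at hand explains this difference. The compounds shown leave open whether a methyl group, an amine or a carboxylic acid in place of that butyl would keep the number high.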